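Ribosyl pyrrolopyrimidines with aryl substituents in a cell assay

The source may report more compounds than this note shows. Statements on the series, on what has been measured and on what is new or still open speak of the compounds shown alone.

Compound 1 `Nc1nc(N)c2c(-c3ccsc3)cn([C@@H]3O[C@H](CO)[C@@H](O)[C@H]3O)c2n1`: > 20000 nM
Compound 2 `Nc1nc(N)c2c(-c3ccccc3)cn([C@@H]3O[C@H](CO)[C@@H](O)[C@H]3O)c2n1`: > 20000 nM
Compound 3 `Nc1nc2c(c(-c3ccccc3)cn2[C@@H]2O[C@H](CO)[C@@H](O)[C@H]2O)c(=O)[nH]1`: > 20000 nM

Three compounds were tested in a functional assay on K562 cells (Homo sapiens), read by MTT assay, with a stated time of 72 h; on this read-out higher numbers stand for weaker inhibition and lower numbers for stronger inhibition. In this assay compound 2 gives only a limit, > 20000 nM, not a number. Compound 1 likewise reaches only a limit, > 20000 nM. Compound 3 also stands at a limit, > 20000 nM. Compound 1 differs from compound 2 by thiophen-3-yl in place of phenyl on an aromatic carbon. The resulting step that the two limits leave unreadable from compound 2 to compound 1 cannot be read because both values sit at the limit of > 20000 nM in this assay, at which 3 of the 3 values shown sit. The difference between the core of compound 2 and the core of compound 3 is not broken down here.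

Compound 4 `Nc1nc2c(c(-c3ccsc3)cn2[C@@H]2O[C@H](CO)[C@@H](O)[C@H]2O)c(=O)[nH]1` is not yet measured. Among the compounds with values here, it differs from compound 3 by thiophen-3-yl in place of phenyl on an aromatic carbon, the same change as the one from compound 2 to compound 1, at the same place. Within the data shown here, since compound 3 stands only at a limit and the earlier instance of this change gave no readable step, no direction for the step from compound 3 to compound 4 can be drawn from these compounds. Compound 4 is therefore expected to stay at the limit as well, with an expected step that the limit leaves unreadable from compound 3 to compound 4 in this assay. Compound 4 is estimated at 30000 nM, within a range of 8000 nM to 100000 nM, and it is expected that this assay will most likely report only a limit for compound 4.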

Compound 4, half-maximal inhibitory concentration: 18300 nM
Estimate against measurement, compound 4: 1.6-fold (0.21 log units) above, and the stated range covers the measured number.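

In this assay, thiophen-3-yl in place of phenyl on the core of compound 3 gives an at least 1.0-fold lower number from compound 3 to compound 4 (0.03 log units; that floor lies within the scatter), so on this core the change shows no step beyond the scatter. Within the data shown here, compound 4, at 18300 nM, is the only one of the four compounds that carries a number rather than a limit, while the same change on the other core, from compound 2 to compound 1, cannot be read, which leaves one readable instance and nothing to set beside it. This does not show that the change behaves alike on the two cores, nor how large the true step on the core of compound 3 is, and the reading is bounded by one fact: the limit of > 20000 nM in this assay, at which 3 of the 4 values shown sit.

The compounds shown leave open how other groups at this place, on an aromatic carbon of the five-membered ring, would read in this assay, for instance an amine, a carboxylic acid or a longer alkyl chain in place of the aromatic ring. They also leave open whether any such group would bring a compound of this series clearly away from the limit.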